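The compounds below may be only part of what the source reports. "The series", "measured", "known", "first", "only" and "open" are said of these compounds alone.

In a functional assay on SH-SY5Y cells (Homo sapiens) for inhibition, read by sulforhodamine B assay (a lower number here means a stronger inhibitor, a higher number a weaker inhibitor), compound 2 (`COC(=O)CC/C(C)=C/Cc1c(OC)c(C)c2c(c1OCC#CCN1CCN(C(=O)C3COc4ccccc4O3)CC1)C(=O)OC2`) gives > 50000 nM as a limit of the assay and not a number. Compound 2 sits at that limit (the limit of > 50000 nM in this assay, at which 1 of the 2 values shown sits). Compound 1 (`COC(=O)CC/C(C)=C/Cc1c(OC)c(C)c2c(c1OCC#CCN1CCN(c3ccc(C#N)cc3)CC1)C(=O)OC2`) gives a real number in this assay (37800 nM). Compound 3 (`COC(=O)CC/C(C)=C/Cc1c(OC)c(C)c2c(c1OCC#CCN1CCN(c3ccc(C)cc3)CC1)C(=O)OC2`) differs from compound 2 by 4-methylphenyl in place of (2,3-dihydro-1,4-benzodioxin-2-yl)carbonyl on an amine nitrogen in a ring with 4-methylphenyl in place of (2,3-dihydro-1,4-benzodioxin-2-yl)carbonyl on an amine nitrogen in a ring. Among the compounds with values here, only one measured step bears on this swap: an at least 1.3-fold higher number from compound 1 to compound 2 (0.12 log units; that floor lies within the scatter) and it is small. Compound 3 carries a substituted phenyl group at that nitrogen, as compound 1 does, so its value is expected to land close to that of compound 1 (37800 nM). The expected step is an at least 1.5-fold lower number from compound 2 to compound 3 (0.19 log units; that floor lies within the scatter) in this assay toward a lower number, if any, and not clearly beyond the scatter. Compound 3 is estimated at 32000 nM within a range from 14000 nM to 50000 nM (expected, not yet measured).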

Compound 3, half-maximal inhibitory concentration: 37700 nM
The estimate for compound 3 lay 1.2-fold (0.07 log units) below the measured number, within the range that was stated.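

Within the data shown here, the result in this assay gives the first comparison of two groups on the phenyl ring at this amine nitrogen: methyl in place of cyano on an aromatic carbon gives a 1.0-fold lower number from compound 1 to compound 3 (0.00 log units; within the scatter) and so compound 1 and compound 3 cannot be told apart here. Placing 4-methylphenyl on the same nitrogen instead of (2,3-dihydro-1,4-benzodioxin-2-yl)carbonyl gives an at least 1.3-fold lower number from compound 2 to compound 3 (0.12 log units; that floor lies within the scatter) as a floor only, so this swap shows no established difference so far. Compound 2 has a limit of the assay and not a number.

From the compounds shown here alone, it stays open whether an amine, a carboxylic acid or a hydroxyl group on that phenyl ring would give a value clearly apart from these. Going by these compounds, how far the true value of compound 2 lies from the phenyl-bearing compounds also stays open.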